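The compounds below may be only part of what the source reports. "The series", "measured", "known", "first", "only" and "open" are said of these compounds alone.

Values in a functional assay on HeLa cells (Homo sapiens) for cytotoxicity, read by MTT assay, with a stated time of 48 h; on this read-out lower numbers stand for stronger inhibition and higher numbers for weaker inhibition:
- compound 1 `COc1cc(/C=C/C(=O)C2=C(/C=C/c3ccc(O)c(OC)c3)NC(=O)NC2c2ccc(C)cc2)ccc1O`: 100000 nM
- compound 2 `COc1cc(/C=C/C(=O)C2=C(/C=C/c3ccc(O)c(OC)c3)NC(=O)NC2c2c(Cl)cccc2Cl)ccc1O`: 25000 nM

Of these two compounds, compound 2 has the lower number, at 25000 nM. Compound 3 `COc1cc(/C=C/C(=O)C2=C(/C=C/c3ccc(O)c(OC)c3)NC(=O)NC2c2ccccc2Cl)ccc1O` differs from it in one place: hydrogen in place of chloro on an aromatic carbon. This is hydrogen in place of chloro on an aromatic carbon, so 2,6-dichlorophenyl becomes 2-chlorophenyl. For the measured compounds named here, only one measured step bears on this change, a 4.0-fold lower number from compound 1 to compound 2 (0.60 log units; beyond the scatter), which replaced 4-methylphenyl with 2,6-dichlorophenyl. That step swaps the whole substituted ring, and no measurement shows the loss of a single chloro alone, so it is only an indirect guide. Going by a 4.0-fold lower number from compound 1 to compound 2 (0.60 log units; beyond the scatter), a smaller move toward a higher number seems likely. The step expected in this assay is a 1.8-fold higher number from compound 2 to compound 3 (0.26 log units; within the scatter). For compound 3 the estimated value is 45000 nM, with an expected range from 20000 nM to 100000 nM.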

Compound 3, half-maximal inhibitory concentration: 100000 nM
Beside the measured number, compound 3's estimate is 2.2-fold (0.35 log units) below it; the measured number falls inside the stated range.
By their numbers in this assay, from the lowest: compound 2; then compounds 1 and 3 (each within the scatter of the next).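

In this assay, taking away one chloro from the 2,6-dichlorophenyl ring gives a 4.0-fold higher number from compound 2 to compound 3 (0.60 log units; beyond the scatter) and so cancels the whole gain seen earlier. A single chloro does not keep the lower number, since going from the 4-methylphenyl ring to the 2-chlorophenyl ring gives no change at the digits printed from compound 1 to compound 3 (within the scatter); among these three compounds, the lower number appears only with both chloro groups in place. Nothing measured here explains this difference.

Still open, as far as these compounds go, is whether another group in place of that chloro, such as a fluoro, a methoxy or an amine, would hold the lower number as the chloro does. The compounds shown also leave open how a single chloro elsewhere on the ring would read.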